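The source may report more compounds than this note shows. Statements on the series, on what has been measured and on what is new or still open speak of the compounds shown alone.

Three compounds share a bicyclic core carrying a hydroxyl and a methoxyphenyl group, and all three have been tested in a functional assay on 786-0 cells (Homo sapiens); on this read-out higher numbers stand for weaker inhibition of growth and lower numbers for stronger inhibition of growth. Compound 1 `COc1ccc(-c2cc(O)c3c(C)cc(C)nc3n2)cc1` gives 58900 nM in this assay. Compound 2 `COc1ccccc1-c1cc(O)c2cccnc2n1` gives 36300 nM in this assay, and compound 3 `COc1ccccc1-c1cc(O)c2c(C)ccnc2n1` gives 60300 nM in this assay. Compound 1 and compound 3 differ in more than one place; the difference between their two cores is not broken down here, and the two values lie within the scatter of each other.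

Compound 3 and compound 2 differ in a single place, described as hydrogen in place of methyl on an aromatic carbon. Going by the values given here, that change produced a 1.7-fold lower number from compound 3 to compound 2 (0.22 log units; within the scatter), so it made no step that can be told apart from repeat measurements.

Compound 4 `COc1ccc(-c2cc(O)c3ccc(C)nc3n2)cc1` has not yet been measured. It arises from compound 1 by hydrogen in place of methyl on an aromatic carbon. Among the compounds with values here, this is the same kind of change as the one from compound 3 to compound 2, though the surroundings differ: in compound 1 the carbon in question is also meta to a methyl group, which is absent around the corresponding carbon of compound 3.

Because the same kind of change gave a 1.7-fold lower number from compound 3 to compound 2 (0.22 log units; within the scatter), the step from compound 1 to compound 4 is expected to be small as well, about a 1.4-fold lower number from compound 1 to compound 4 (0.15 log units; within the scatter). Compound 4 is therefore estimated to give 42000 nM in this assay, with a likely range from 20000 nM to 90000 nM.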

Compound 4, concentration for 50% growth inhibition: > 100000 nM
Compound 4 gave a limit, no number; the forecaster's own chance of this, stated with the estimate: 10%; middle value at least 2.3-fold (0.37 log units) away from the limit.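

In this assay, compound 4 gives > 100000 nM, which is a limit of the assay and not a number: the limit of > 100000 nM in this assay, at which 1 of the 4 values shown sits. Taking the methyl off the core of compound 1 therefore gives only a floor for the step, an at least 1.6-fold higher number from compound 1 to compound 4 (0.22 log units; that floor lies within the scatter), and this result shows that the change does not carry over cleanly from one core to the other, even though each step alone is small: the same change on two cores in this assay, a 1.7-fold lower number (0.22 log units; within the scatter) from compound 3 to compound 2 and an at least 1.6-fold higher number (0.22 log units; that floor lies within the scatter) from compound 1 to compound 4, at least 2.8-fold (0.45 log units) apart, beyond the scatter of two such steps. This does not show which difference between the two cores is responsible, as compound 1 and compound 3 differ in more than one place, and two cores give no rule for how the change will behave on a third.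

Going by these compounds, the true size of the step from compound 1 to compound 4 stays open, as the limit fixes only its lower end. Only methyl and hydrogen appear on this aromatic carbon among the compounds shown, so it also remains open how an ethyl group, a chlorine atom or an amine at that carbon would behave on either core in this assay.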